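The compounds below may be only part of what the source reports. "The series", "measured", "known", "first", "only" and "open" are said of these compounds alone.

Measured compounds:
- compound 1, `CCS(=O)(=O)N1CC(Oc2cncc(N3C(=O)c4ccc(Cl)cc4C3(C)C)c2)C1`: 5 mL/min/kg
- compound 2, `CCS(=O)(=O)N1CC2(CN(c3cncc(N4C(=O)c5ccc(Cl)cc5C4(C)C)c3)C2)C1`: 0.87 mL/min/kg

In an ADME assay on microsomes from liver (Rattus norvegicus) for metabolic stability, read by LC-MS, using NADPH, with stated times of 10 min and 30 min (a lower number here means slower removal, a higher number faster removal of the compound), compound 1 gives 5 mL/min/kg, the higher of the two numbers in hand. Compound 2 gives 0.87 mL/min/kg in this assay, a lower number than compound 1 by a margin beyond the usual scatter. For the measured compounds named here, the two share the core of compound 1 and differ in more than one place, so no single step is drawn between them.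

Compound 3, `Cc1ccncc1C(=O)N1CC(Oc2cncc(N3C(=O)c4ccc(Cl)cc4C3(C)C)c2)C1`, is not yet measured. It differs from compound 1 at one site: (4-methylpyridin-3-yl)carbonyl in place of ethylsulfonyl on an amine nitrogen in a ring. Going by the values given here, no measured pair covers this change, so the size of the step has to be guessed from compound 1 alone. The step from compound 1 to compound 3 in this assay is expected to be a rise, a 2.4-fold higher number from compound 1 to compound 3 (0.38 log units; beyond the scatter), probably beyond the scatter. Compound 3 is therefore estimated at 12 mL/min/kg, with a range from 4 mL/min/kg to 35 mL/min/kg.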

Compound 3, clearance: 10.4 mL/min/kg
Estimate against measurement, compound 3: 1.2-fold (0.06 log units) above; the measured number falls inside the stated range.
By their numbers in this assay, from the lowest: compound 2; then compound 1; then compound 3.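

In this assay, for the compounds shown here, (4-methylpyridin-3-yl)carbonyl in place of ethylsulfonyl on the amine nitrogen of the four-membered ring gives a 2.1-fold higher number from compound 1 to compound 3 (0.32 log units; beyond the scatter) and provides the only single-site reading at this position. The step is modest, so this nitrogen carries a larger group with a six-membered aromatic ring while the clearance stays within a modest step of compound 1. Nothing measured here accounts for the rise.

On these data alone, it remains open whether the step follows the aromatic ring, its methyl or the carbonyl, and a benzoyl or an acetyl on the same nitrogen would help separate these. Compound 2 differs from compound 1 in more than one place, so the contribution of each of its differences also remains unresolved.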